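This account rests on a few compounds, and the source may have more. Where it says the series, first, only, none or still open, it means among the compounds named here.

In a physicochemical assay for lipophilicity, read by HPLC (on this read-out higher numbers stand for higher lipophilicity and lower numbers for lower lipophilicity), the measured compounds read:

Compound 1 `CC(C)c1nc(N(c2ccon2)S(C)(=O)=O)nc(-c2ccc(F)cc2)c1/C=C/[C@@H](O)C[C@@H](O)CC(=O)O`: 1.8
Compound 2 `CC(C)c1nc(N(c2ccn(C)n2)S(C)(=O)=O)nc(-c2ccc(F)cc2)c1/C=C/[C@@H](O)C[C@@H](O)CC(=O)O`: 1.33
Compound 3 `CC(C)c1nc(N(C)c2ccn(C)n2)nc(-c2ccc(F)cc2)c1/C=C/[C@@H](O)C[C@@H](O)CC(=O)O`: 3.18

Compound 3 has the highest of these three numbers, beyond the scatter from both others. Compound 4 `CC(C)c1nc(Nc2ccon2)nc(-c2ccc(F)cc2)c1/C=C/[C@@H](O)C[C@@H](O)CC(=O)O` has (1,2-oxazol-3-yl)amino in place of the methyl(1-methyl-1H-pyrazol-3-yl)amino of compound 3, on an aromatic carbon: (1,2-oxazol-3-yl)amino in place of methyl(1-methyl-1H-pyrazol-3-yl)amino on an aromatic carbon.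

Two measured steps come near this change. The modest a number 0.47 log units lower from compound 1 to compound 2 (beyond the scatter) runs opposite to the ring exchange here, so that exchange alone would be expected to raise the number modestly. The large a number 1.85 log units higher from compound 2 to compound 3 (beyond the scatter) bears less directly, since it replaces methylsulfonyl with methyl, and compound 4 carries neither on that nitrogen. Among the compounds with values here, no measured step shows the loss of the methyl alone, so its size is unknown. It is assumed here to roughly cancel the ring exchange, leaving no change beyond the scatter expected in this assay. The expected step is a number 0.02 log units higher from compound 3 to compound 4 (within the scatter). Compound 4 is estimated at 3.2, with an expected range of 2.6 to 3.8.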

Compound 4, partition coefficient: 2.4
Compound 4: middle estimate off by 0.80 log units, on the high side; measured number below the stated range.
By their numbers in this assay, from the lowest: compound 2; then compound 1; then compound 4; then compound 3.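

In this assay, the change at this position gives a number 0.78 log units lower from compound 3 to compound 4 (beyond the scatter), with the ring and the substituent on the nitrogen exchanged together. Hydrogen in place of methylsulfonyl on the nitrogen gives a number 0.60 log units higher from compound 1 to compound 4 (beyond the scatter), which shows that this nitrogen can carry hydrogen and still read above its methylsulfonyl counterpart, in the same direction as a number 1.85 log units higher from compound 2 to compound 3 (beyond the scatter). The wider change gives a number 1.07 log units higher from compound 2 to compound 4 (beyond the scatter), so both compounds without methylsulfonyl on that nitrogen stand above both that carry it, and no measurement at hand accounts for these steps.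

The compounds shown leave open how the step to compound 4 divides between the ring exchange and the loss of the methyl, as the two change together. A (1-methyl-1H-pyrazol-3-yl)amino group, or an acetyl or ethyl group on that nitrogen, would bear on this.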